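Hydroxyalkyl triazole series: methyl addition at the carbinol carbon

The source may report more compounds than this note shows. Statements on the series, on what has been measured and on what is new or still open speak of the compounds shown alone.

Measured so far:
compound 1 `CC(C)(C)c1cn(CCNc2nonc2/C(=N/O)Nc2ccc(F)c(Br)c2)nn1` — 1870 nM
compound 2 `OCCCc1cn(CCNc2nonc2/C(=N/O)Nc2ccc(F)c(Br)c2)nn1` — 958 nM
compound 3 `CC(O)c1cn(CCNc2nonc2/C(=N/O)Nc2ccc(F)c(Br)c2)nn1` — 362 nM

All three share one core and differ only in the substituent on the aromatic carbon of the triazole. In an assay on isolated protein for inhibition of Indoleamine 2,3-dioxygenase 2 (Homo sapiens) (a lower number here means a stronger inhibitor, a higher number a weaker inhibitor), compound 3 gives 362 nM, the lowest of the three numbers; the steps of a 2.6-fold lower number from compound 2 to compound 3 (0.42 log units; beyond the scatter) and a 5.2-fold lower number from compound 1 to compound 3 (0.71 log units; beyond the scatter) both lie beyond the scatter, so compound 3 stands as the strongest inhibitor measured here. The step of a 2.0-fold lower number from compound 1 to compound 2 (0.29 log units; within the scatter) is within the scatter.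

Compound 4 `CC(C)(O)c1cn(CCNc2nonc2/C(=N/O)Nc2ccc(F)c(Br)c2)nn1` is not yet measured. It differs from compound 3 by methyl in place of hydrogen on a saturated chain carbon bound to an aromatic carbon, an oxygen on a saturated carbon and a saturated chain carbon. Among the compounds with values here, no measured step carries this exact change. The nearest guide is the step of a 5.2-fold lower number from compound 1 to compound 3 (0.71 log units; beyond the scatter), in which a tert-butyl gave way to a 1-hydroxyethyl: compound 4 keeps the hydroxyl of compound 3 but adds a methyl on the same carbon, moving it part of the way back toward compound 1. The expectation is therefore a small step in this assay, if any, toward a higher number, a 1.5-fold higher number from compound 3 to compound 4 (0.18 log units; within the scatter), not clearly beyond the scatter. Compound 4 is estimated at 550 nM, with a range of 220 nM to 1400 nM.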

Compound 4, half-maximal inhibitory concentration: 726 nM
The estimate for compound 4 lay 1.3-fold (0.12 log units) below the measured number; the measured number falls inside the stated range.
By their numbers in this assay, from the lowest: compounds 3, 4, 2 and 1 (each within the scatter of the next, the first and the last beyond it).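

In this assay, methyl in place of hydrogen on the saturated chain carbon bound to the aromatic carbon gives a 2.0-fold higher number from compound 3 to compound 4 (0.30 log units; within the scatter), so this position accepts the 1-hydroxy-1-methylethyl group without a difference that can be told from the scatter. Against the straight chain, a 1.3-fold lower number from compound 2 to compound 4 (0.12 log units; within the scatter), which leaves 1-hydroxy-1-methylethyl and 3-hydroxypropyl indistinguishable here. Within the data shown here, the sharpest new information comes from the pair that differs only by hydroxy in place of methyl, with a 2.6-fold lower number from compound 1 to compound 4 (0.41 log units; beyond the scatter) beyond the scatter, whereas the earlier steps from tert-butyl also altered the carbon skeleton of the substituent. No measurement at hand explains any of these steps.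

Still open, on these data alone, is whether an amine or a methoxy group in place of the hydroxy on this carbon would keep numbers in the range of compound 3 and compound 4, and whether a longer chain such as ethyl in place of the added methyl would do the same. Compound 3 is also drawn without a defined configuration at this carbon, so the separate mirror-image forms of the 1-hydroxyethyl group remain unresolved.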